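This account rests on a few compounds, and the source may have more. Where it says the series, first, only, none or still open, it means among the compounds named here.

Measured so far:
compound 1 `COC(=O)/C=C/c1cccc(N(Cc2ccc(-c3cccc(Cl)c3)cc2)C(=O)C2CCCCC2)c1` — 94 nM
compound 2 `COC(=O)/C=C/c1cccc(N(Cc2ccc(/C=C/C(=O)OC(C)(C)C)cc2)C(=O)NC(C)C)c1` — 212 nM

In an assay on isolated protein with Bile acid receptor (Homo sapiens) as the target (on this read-out lower numbers stand for an effect already at smaller amounts and higher numbers for an effect only at larger amounts of compound), compound 2 gives the higher of the two numbers; compound 1 gives 94 nM, a gap beyond the usual scatter. Compound 3 `COC(=O)/C=C/c1cccc(N(Cc2ccc(-c3cccc(Cl)c3)cc2)C(=O)NC(C)C)c1` is not yet measured. It differs from compound 2 in one place: 3-chlorophenyl in place of 2-(tert-butoxycarbonyl)ethenyl on an aromatic carbon. Among the compounds with values here, no single-change pair with this exact swap has been measured, so the size of the step is open. Since compound 1, which carries the same 3-chlorophenyl group, gives 94 nM, a modest downward step is expected, a 1.6-fold lower number from compound 2 to compound 3 (0.21 log units; within the scatter), though a move within the scatter cannot be ruled out. Compound 3 is estimated at 130 nM, with a range from 50 nM to 350 nM.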

Compound 3, half-maximal effective concentration: 1400 nM
The estimate for compound 3 lay 11-fold (1.03 log units) below the measured number; measured number above the stated range.
By their numbers in this assay, from the lowest: compound 1; then compound 2; then compound 3.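

In this assay the 3-chlorophenyl group does not bring a low number on its own: with isopropylamino on the carbonyl carbon, replacing 2-(tert-butoxycarbonyl)ethenyl gives a 6.6-fold higher number from compound 2 to compound 3 (0.82 log units; beyond the scatter). Isopropylamino in place of cyclohexyl gives a 15-fold higher number from compound 1 to compound 3 (1.17 log units; beyond the scatter), so the aromatic-carbon group is best read together with the group on the carbonyl carbon. No supporting data explain either step.

Open, on these data alone, is how cyclohexyl on the carbonyl carbon would read alongside 2-(tert-butoxycarbonyl)ethenyl. Also open, as far as these compounds go, is how a carboxylic acid at the aromatic position would read.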